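Notes on the cyclopropane diamide series, toward compound 4

A few compounds are considered here, and "the series" means these few. Any claim that something is new, unique, unknown or untested is made for them only; others in the source may bear on it.

Measured so far:
- Compound 1, `CN(C)C(=O)c1cc2cnc(Nc3ccc(NC(=O)C4(C(=O)Nc5cccc(O)c5)CC4)cc3)nc2n1C1CCCC1`: in a functional assay on NCI-H460 cells (Homo sapiens) for inhibition, read by CCK-8 assay, with a stated time of 72 h, tested at 10 uM (on this read-out lower numbers stand for less inhibition of growth and higher numbers for more inhibition of growth at the one concentration tested), compound 1 gives 94.9%.
- Compound 2, `CN(C)C(=O)c1cc2cnc(Nc3ccc(NC(=O)C4(C(=O)Nc5ccc(Br)cc5)CC4)cc3)nc2n1C1CCCC1`: in this assay compound 2 gives 96.4%.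
- Compound 3, `CN(C)C(=O)c1cc2cnc(Nc3ccc(NC(=O)C4(C(=O)Nc5ccc(Cl)c(C(F)(F)F)c5)CC4)cc3)nc2n1C1CCCC1`: in this assay compound 3 gives 91.9%.

Compound 3 holds the lowest of the three numbers, but only within the scatter: the step of a number 3 percentage points lower from compound 1 to compound 3 (within the scatter) and the step of a number 4.5 percentage points lower from compound 2 to compound 3 (within the scatter) are both small, as is a number 1.5 percentage points higher from compound 1 to compound 2 (within the scatter). On these numbers the three aryl groups on the amide-type nitrogen cannot be told apart.

Compound 4, `CN(C)C(=O)c1cc2cnc(Nc3ccc(NC(=O)C4(C(=O)Nc5ccc(Cl)cc5)CC4)cc3)nc2n1C1CCCC1`, has not yet been measured. From compound 3 to compound 4 the change is hydrogen in place of trifluoromethyl on an aromatic carbon; read one bond further out, it is 4-chloro-3-(trifluoromethyl)phenyl to 4-chlorophenyl. Going by the values given here, no measured pair removes a trifluoromethyl on its own. The closest comparison is the exchange of one aryl group for another between compound 2 and compound 3, a number 4.5 percentage points lower from compound 2 to compound 3 (within the scatter), and the exchange between compound 1 and compound 3, a number 3 percentage points lower from compound 1 to compound 3 (within the scatter). Both stay within the scatter, so a change confined to one trifluoromethyl is expected to give a number 2.1 percentage points higher from compound 3 to compound 4 (within the scatter), that is, no step beyond the scatter in either direction. Compound 4 is therefore estimated at 94%, within 87% to 99%.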

Compound 4, percent growth inhibition at one concentration: 95.7%
Beside the measured number, compound 4's estimate is 1.7 percentage points below it; the measured number falls inside the stated range.
By their numbers in this assay, from the lowest: compounds 3, 1, 4 and 2 (each within the scatter of the next).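

In this assay, going by these compounds alone, taking the trifluoromethyl off the 4-chloro-3-(trifluoromethyl)phenyl group gives a number 3.8 percentage points higher from compound 3 to compound 4 (within the scatter), the first change confined to this aromatic carbon ortho to a chloro group; on this read-out, the position accepts either trifluoromethyl or hydrogen without a step beyond the scatter. The new compound also adds two comparisons at the aryl group on the amide-type nitrogen: chloro in place of bromo gives a number 0.7 percentage points lower from compound 2 to compound 4 (within the scatter), and 4-chlorophenyl in place of 3-hydroxyphenyl gives a number 0.8 percentage points higher from compound 1 to compound 4 (within the scatter), so neither exchange separates the compounds either. No supporting measurement bears on this result, and these numbers alone offer no explanation for it.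

Still open, going by these compounds, is whether an amine or a carboxylic acid in place of the hydrogen on this aromatic carbon, or a longer chain in place of the aryl group on the amide-type nitrogen, would produce a step beyond the scatter. Also open, on these data alone, is whether these four compounds, which cannot be told apart at the one concentration tested, would remain so at lower concentrations.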